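Replacing the butyl group of compound 2

The source may report more compounds than this note shows. Statements on the series, on what has been measured and on what is new or still open speak of the compounds shown alone.

In a functional assay on A549 cells (Homo sapiens) for inhibition, read by MTT assay, with a stated time of 72 h (a lower number here means a stronger inhibitor, a higher number a weaker inhibitor), compound 2 (`CCCCc1ccc(NC(=O)C2CCN(C/C=C/c3ccccc3)CC2)cc1`) gives 5910 nM, the lowest of three numbers and beyond the scatter of the other two. Compound 3 (`O=C(Nc1cccc(Cl)c1)C1CCN(C/C=C/c2ccccc2)CC1`) gives 19100 nM, and compound 1 (`Cc1ccc(NC(=O)C2CCN(C/C=C/c3ccccc3)CC2)cc1`) gives 29600 nM. Compound 4 (`CN1CCN(c2ccc(NC(=O)C3CCN(C/C=C/c4ccccc4)CC3)cc2)CC1`) differs from compound 2 as follows: 4-methylpiperazin-1-yl in place of butyl on an aromatic carbon. The most relevant measurement is a 5.0-fold lower number from compound 1 to compound 2 (0.70 log units; beyond the scatter). Removing the butyl group may give back part of that step, while a 1.5-fold lower number from compound 1 to compound 3 (0.19 log units; within the scatter) offers little guidance. Among the measured compounds shown here, no measured compound carries a 4-methylpiperazin-1-yl group. A modest step to a higher number in this assay is therefore expected, smaller than the step that gained the butyl group. The expected change is a 2.2-fold higher number from compound 2 to compound 4 (0.34 log units; beyond the scatter). For compound 4, the estimate is 13000 nM, with an expected range of 4000 nM to 40000 nM.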

Compound 4, half-maximal inhibitory concentration: 19900 nM
For compound 4 the middle estimate is 1.5-fold (0.18 log units) below the measured one; low and high end bracket the measured number.
By their numbers in this assay, from the lowest: compound 2; then compounds 3, 4 and 1 (each within the scatter of the next).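

In this assay, exchanging butyl for 4-methylpiperazin-1-yl on this aromatic carbon gives a 3.4-fold higher number from compound 2 to compound 4 (0.53 log units; beyond the scatter), so the gain seen with butyl does not carry over to this larger group. Against methyl, the same group gives a 1.5-fold lower number from compound 1 to compound 4 (0.17 log units; within the scatter), so heavy-atom count alone does not track the number across compounds 1, 2 and 4, with compound 4 going against any such trend. No measurement available here explains the difference between these groups.

On these data alone, it remains open whether the lower number of compound 2 depends on chain length or on an all-carbon group. A hexyl chain and a morpholin-4-yl ring at this position would help separate these two readings.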